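This account rests on a few compounds, and the source may have more. Where it says the series, first, only, none or still open, it means among the compounds named here.

Measured so far:
compound 1, `CC(C)(C)c1cc(N)c2cc(NC(=O)/C=C/c3ccc(C(F)(F)F)cc3)ccc2n1`: 29 nM
compound 2, `CCCc1cc(NC)c2cc(NC(=O)/C=C/c3ccc(C(F)(F)F)cc3)ccc2n1`: 150 nM

Both were tested in a functional assay on HEK293 cells for activation of melanin-concentrating hormone receptor 1 (Homo sapiens), read by inositol phosphate accumulation; on this read-out higher numbers stand for an effect only at larger amounts of compound and lower numbers for an effect already at smaller amounts. Compound 1 gives 29 nM in this assay, the lower of the two numbers. Compound 2 gives 150 nM, and the gap between the two lies beyond the usual scatter. Compound 2 differs from compound 1 in two places at once, so no single structural change can be read from that pair.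

Compound 3, `CCC(C)c1cc(N)c2cc(NC(=O)/C=C/c3ccc(C(F)(F)F)cc3)ccc2n1`, has not yet been measured. It differs from compound 1 in one place only: sec-butyl in place of tert-butyl on an aromatic carbon, in words sec-butyl in place of tert-butyl on an aromatic carbon, next to the ring nitrogen of the shared core. The two compounds hold the same atoms, joined differently. Within the data shown here, no measured pair shows such a change, so the expectation rests on the size of the group alone, which stays the same. In this assay the step of a 1.6-fold higher number from compound 1 to compound 3 (0.19 log units; within the scatter) is expected to be small, at most a modest move upward, and possibly none beyond the scatter. Compound 3 is therefore estimated at 45 nM, with a range from 15 nM to 150 nM.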

Compound 3, half-maximal effective concentration: 44 nM
Compound 3: middle estimate off by 1.0-fold (0.01 log units), on the high side; the range from low to high includes it.
By their numbers in this assay, from the lowest: compounds 1 and 3 (each within the scatter of the next); then compound 2.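

Among these compounds, this is the first pair that differs in one place only, so it gives the first direct reading of the group on the aromatic carbon next to the ring nitrogen: in this assay, sec-butyl in place of tert-butyl gives a 1.5-fold higher number from compound 1 to compound 3 (0.18 log units; within the scatter) and so stays inside the normal noise of the measurement. Among the compounds shown here, at this place the assay therefore does not separate these two groups, which hold the same atoms joined differently, and tert-butyl is not the only group here that reaches this level of the read-out. No separate measurement bears on this result.

Still open, on these data alone, is how much this place accepts beyond these two butyl groups: a small methyl, a ring such as cyclohexyl or phenyl, or a chain ending in an amine or a carboxylic acid could each give a quite different number. For the compounds shown here, compound 2 carries a propyl chain and a methylamino group together, so the share of each in its gap to compound 1 remains unknown, and a compound with only one of these changes would separate them.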